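Exchanging Methoxy for Formyl on the Aromatic Ring

The compounds below may be only part of what the source reports. "The series", "measured", "known", "first", "only" and "open" are said of these compounds alone.

In an assay on CHO cells with Alpha-2C adrenergic receptor (Homo sapiens) as the target (a lower number here means a smaller maximal response, a higher number a larger maximal response), three compounds have been measured so far:
compound 1 `CCOc1ccccc1OC(C)C1=NCCN1` gives 0.45
compound 2 `CC(=O)c1ccccc1OC(C)C1=NCCN1` gives 0.65
compound 3 `COc1ccccc1OC(C)C1=NCCN1` gives 0.6

Compound 3 stands second highest of the three. Its gap to compound 2 is small, a number 0.050 lower from compound 2 to compound 3 (within the scatter), while its gap to compound 1 is larger, a number 0.15 higher from compound 1 to compound 3 (beyond the scatter). Compound 4 `CC(Oc1ccccc1C=O)C1=NCCN1` differs from compound 3 in one place: formyl in place of methoxy on an aromatic carbon. The measured step that bears most on this change is the one in which methoxy replaced acetyl on the same aromatic carbon, a number 0.050 lower from compound 2 to compound 3 (within the scatter), a swap of one small oxygen-bearing group for another that left the response essentially unchanged. The exchange of methoxy for formyl is likewise expected to move the number little, a number 0.030 higher from compound 3 to compound 4 (within the scatter). Compound 4 is therefore estimated at 0.63, in the range 0.5 to 0.78.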

Compound 4, intrinsic activity: the largest response reached, as a fraction of the reference agonist's: 0.6
Compound 4: the middle estimate sits 0.030 above what was measured, within the range that was stated.
By their numbers in this assay, from the lowest: compound 1; then compounds 3, 4 and 2 (each within the scatter of the next).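

Formyl can stand in for methoxy on this aromatic carbon with no change at the digits printed from compound 3 to compound 4 (within the scatter) in this assay. Removing the methyl from the acetyl carbonyl carbon gives a number 0.050 lower from compound 2 to compound 4 (within the scatter), so methoxy, acetyl and formyl all lie within the scatter of one another here, while ethoxy stands apart, as formyl in its place gives a number 0.15 higher from compound 1 to compound 4 (beyond the scatter). Nothing available explains why these groups give such similar responses. Still open, going by these compounds, is how an amine or a carboxylic acid on this carbon would behave, and whether an alkoxy chain longer than ethoxy would lower the response further.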